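A few compounds are considered here, and "the series" means these few. Any claim that something is new, unique, unknown or untested is made for them only; others in the source may bear on it.

Of the compounds shown here, three on a shared core have been measured in a functional assay on MCF7 cells (Homo sapiens) for cytotoxicity, read by MTT assay, with a stated time of 48 h; on this read-out lower numbers stand for stronger inhibition and higher numbers for weaker inhibition; they differ only in the group on one of the aryl rings. Compound 1 `O=C(Nc1ccc(Cl)cc1)c1cn(-c2ccccc2)nc1-c1ccc(Cl)cc1` gives 3750 nM. Compound 2 `O=C(Nc1ccc(Br)cc1)c1cn(-c2ccccc2)nc1-c1ccc(Cl)cc1` gives 5310 nM in this assay. Compound 3 `COc1ccc(NC(=O)c2cn(-c3ccccc3)nc2-c2ccc(Cl)cc2)cc1` gives 1550 nM in this assay. Compound 3 stands lowest of the three numbers: the step of a 2.4-fold lower number from compound 1 to compound 3 (0.38 log units; beyond the scatter) and the step of a 3.4-fold lower number from compound 2 to compound 3 (0.53 log units; beyond the scatter) both run beyond the scatter, while the step of a 1.4-fold higher number from compound 1 to compound 2 (0.15 log units; within the scatter) stays within it.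

Compound 4 `COc1ccc(NC(=O)c2cn(-c3ccccc3)nc2-c2ccc([N+](=O)[O-])cc2)cc1` keeps the methoxy group of compound 3 and alters the other aryl ring: nitro in place of chloro on an aromatic carbon. Going by the values given here, none of the measured steps touches this ring; all three exchange the group on the ring that carries the methoxy in compound 3, so they give no direct reading of how a move from 4-chlorophenyl to 4-nitrophenyl shifts the number in this assay. What they do show is that a single-point swap on an aryl ring in this series moves the read-out by modest amounts or not at all. The step of a 1.3-fold higher number from compound 3 to compound 4 (0.11 log units; within the scatter) is therefore expected to be small, its direction undetermined. Compound 4 is expected at 2000 nM, with a range from 600 nM to 7000 nM in this assay.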

Compound 4, half-maximal inhibitory concentration: 1210 nM
Compound 4: middle estimate off by 1.7-fold (0.22 log units), on the high side; measured number inside the range.
By their numbers in this assay, from the lowest: compounds 4 and 3 (each within the scatter of the next); then compounds 1 and 2 (each within the scatter of the next).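

In this assay, going by these compounds alone, the change from 4-chlorophenyl to 4-nitrophenyl gives a 1.3-fold lower number from compound 3 to compound 4 (0.11 log units; within the scatter), the first step read at this ring, since the earlier steps all exchanged the group on the other aryl ring. With the methoxy group held constant, this position takes nitro, with 3 heavy atoms and 2 hydrogen-bond acceptors, in place of chloro, with 1 heavy atom and 0 hydrogen-bond acceptors, and the number stays within the scatter, so this single exchange offers no sign that the read-out depends on which of these two groups sits here. No supporting data bear on why the number holds across this exchange.

As far as these compounds go, this reading rests on one pair of compounds, so it remains open whether an amine, a carboxylic acid or a longer alkoxy chain at this place would also leave the number unchanged. It also remains open whether the same exchange would read alike with chloro or bromo on the other aryl ring rather than methoxy, as the compounds shown pair nitro with methoxy only.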